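Sulfur-to-selenium swap on a benzylic thiocyanate

A few compounds are considered here, and "the series" means these few. Any claim that something is new, unique, unknown or untested is made for them only; others in the source may bear on it.

Measured so far:
- compound 1 `Cc1noc(C)c1CSC#N`: 74200 nM
- compound 2 `Cc1noc(C)c1C[Se]C#N`: 4000 nM
- compound 3 `N#CSCc1ccc(-n2cccc2)cc1`: 23500 nM

All numbers come from a toxicity assay on 184B5 cells (Homo sapiens) for cytotoxicity, read by MTT assay, with a stated time of 72 h; a lower number here means a stronger inhibitor of growth, a higher number a weaker inhibitor of growth. Compound 1 and compound 2 share one core, compound 3 and compound 4 `N#C[Se]Cc1ccc(-n2cccc2)cc1` another; the difference between the two cores is not broken down here. Within the first pair, the only change is a group of 3 heavy atoms (1 carbon, 1 nitrogen, 1 selenium; no ring) in place of a group of 3 heavy atoms (1 carbon, 1 nitrogen, 1 sulfur; no ring), on a saturated chain carbon bound to an aromatic carbon, and it gave a 19-fold lower number from compound 1 to compound 2 (1.27 log units; beyond the scatter). From compound 3 to compound 4 the change is a group of 3 heavy atoms (1 carbon, 1 nitrogen, 1 selenium; no ring) in place of a group of 3 heavy atoms (1 carbon, 1 nitrogen, 1 sulfur; no ring), on a saturated chain carbon bound to an aromatic carbon, the same change on the same kind of place. Compound 3 sits in this assay with a higher number than compound 2 and a lower number than compound 1.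

Among the measured compounds shown here, only one precedent exists for the change, so the expectation for compound 4 rests on that single step. The step from compound 3 to compound 4 is expected to be about a 16-fold lower number from compound 3 to compound 4 (1.19 log units; beyond the scatter), close in size to the step from compound 1 to compound 2. Compound 4 is therefore estimated at 1500 nM, with a range from 500 nM to 6000 nM to allow for the change transferring less fully to the second core.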

Compound 4, concentration for total growth inhibition: > 100000 nM
Compound 4: no number, only a limit; the forecaster's own chance of this, stated with the estimate: 5%; at least 66-fold (1.82 log units) between middle value and limit.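

Compound 4 gives > 100000 nM in this assay, which is a limit of the assay and not a number. On this core, selenium in place of sulfur gives an at least 4.2-fold higher number from compound 3 to compound 4 (0.62 log units; beyond the scatter), so the size of the step is bounded on one side only, and two cores are too few to support a rule for the series or to show which feature of either core decides the outcome. The direction of the change does not carry from the core of compound 1 to the core of compound 3: the same change on two cores in this assay, a 19-fold lower number (1.27 log units; beyond the scatter) from compound 1 to compound 2 and an at least 4.2-fold higher number (0.62 log units; beyond the scatter) from compound 3 to compound 4, at least 78-fold (1.89 log units) apart, beyond the scatter of two such steps.

Still open, from the compounds shown here alone, is which of the two outcomes the same swap would follow on further cores, for example a core bearing an amine or a carboxylic acid. Also open, going by these compounds, is whether the split between the two cores would persist with a longer chain in place of the saturated chain carbon that carries the cyanosulfanyl group or its selenium counterpart.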